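A Methyl Group on the Anilino Ring of Compound 1

The source may report more compounds than this note shows. Statements on the series, on what has been measured and on what is new or still open speak of the compounds shown alone.

Compound 1 `Fc1cccc(-c2nc(Nc3ccccc3)c3cc(F)ccc3n2)c1` is a weak inhibitor in a functional assay on COLO 205 cells (Homo sapiens) for cytotoxicity, read by MTT assay, with a stated time of 48 h (a higher number here means a weaker inhibitor, a lower number a stronger inhibitor), where compound 1 gives 49700 nM, the highest of the two numbers measured here. Compound 2 `Fc1cccc(-c2nc(Nc3ccc(Cl)cc3)c3cc(F)ccc3n2)c1` carries chloro in place of hydrogen on an aromatic carbon; in this assay compound 2 gives 32600 nM, and the step of a 1.5-fold lower number from compound 1 to compound 2 (0.18 log units; within the scatter) is small. Compound 3 `Oc1cccc(Nc2nc(-c3cccc(F)c3)nc3ccc(F)cc23)c1` carries hydroxy in place of hydrogen on an aromatic carbon. In this assay compound 3 gives > 50000 nM, which is a limit of the assay rather than a number. The step of a number no lower from compound 1 to compound 3 (the limit leaves the size open) therefore cannot be sized, and that limit is the limit of > 50000 nM in this assay, at which 1 of the 3 values shown sits.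

Compound 4 `Cc1cccc(Nc2nc(-c3cccc(F)c3)nc3ccc(F)cc23)c1` differs from compound 1 by methyl in place of hydrogen on an aromatic carbon. The two measured steps from compound 1 both swap hydrogen on an aromatic carbon for a small group, and neither moved the number beyond the scatter or gave a readable change in the stronger direction. A methyl group is expected to do no more, so the step of a 1.1-fold lower number from compound 1 to compound 4 (0.04 log units; within the scatter) is expected to stay within the scatter. Compound 4 is therefore estimated at 45000 nM, with a range from 20000 nM to 100000 nM in this assay, and with a real chance that only a limit is returned.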

Compound 4, half-maximal inhibitory concentration: > 50000 nM
Compound 4 gave a limit, no number; the forecaster's own chance of this, stated with the estimate: 35%; middle value at least 1.1-fold (0.04 log units) away from the limit.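

In this assay, the 3-methylphenyl group of compound 4, like the 3-hydroxyphenyl group of compound 3, returns only a limit of the assay, so neither of these two small groups, set meta to a large group, gives a lower number than the plain phenyl ring of compound 1, and this limit now reads: the limit of > 50000 nM in this assay, at which 2 of the 4 values shown sit. Against the plain phenyl ring, the result reads as a number no lower from compound 1 to compound 4 (the limit leaves the size open) and gives no size. Against the 4-chlorophenyl group of compound 2, the result reads as an at least 1.5-fold higher number from compound 2 to compound 4 (0.18 log units; that floor lies within the scatter), so even the one step that can be partly sized does not clear the scatter. From the compounds shown here alone, the steps from compound 1 and from compound 3 to compound 4 cannot be read, which means that the methyl group's true effect on the number stays unknown, in either direction.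

Going by these compounds, how far compound 3 and compound 4 lie past the limit remains open, as does whether the methyl group would behave differently on the ring carbon that carries chloro in compound 2. Also open, on these data alone, is whether an amine, a carboxylic acid or a longer chain at this place would bring the number clearly down into the measurable range.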